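Amide aryl variation on the shared core: compound 4

The source may report more compounds than this note shows. Statements on the series, on what has been measured and on what is new or still open speak of the compounds shown alone.

Among the compounds with values here, in a functional assay on HCC1937 cells (Homo sapiens) for antiproliferative activity, read by CCK-8 assay, with a stated time of 72 h (on this read-out higher numbers stand for weaker inhibition and lower numbers for stronger inhibition), compound 1 `Cc1ccc(C(=O)Nc2cccc(-c3oc4cc(-c5ccc(F)cc5)ccc4c(=O)c3O)c2)cc1` gives 7110 nM, the highest of the three numbers measured so far, though neither of the other two lies beyond the scatter of it. Compound 2 `COc1cc(OC)cc(C(=O)Nc2cccc(-c3oc4cc(-c5ccc(F)cc5)ccc4c(=O)c3O)c2)c1` gives 6250 nM in this assay, and compound 3 `O=C(Nc1cccc(-c2oc3cc(-c4ccc(F)cc4)ccc3c(=O)c2O)c1)c1ccc([N+](=O)[O-])cc1` gives 5640 nM. The three changes that separate them all sit on the carbonyl carbon of the amide: a 1.1-fold lower number from compound 1 to compound 2 (0.06 log units; within the scatter), a 1.3-fold lower number from compound 1 to compound 3 (0.10 log units; within the scatter) and a 1.1-fold lower number from compound 2 to compound 3 (0.04 log units; within the scatter), each within the scatter, so the aryl group on the amide has so far made no difference that can be told from repeat measurements.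

Compound 4 `O=C(Nc1cccc(-c2oc3cc(-c4ccc(F)cc4)ccc3c(=O)c2O)c1)c1ccc(-c2ccccc2)cc1` differs from compound 1 by phenyl in place of methyl on an aromatic carbon. Within the data shown here, no measured step introduces a phenyl here; the nearest precedents are the three amide-aryl swaps above, all of which left the number unchanged within the scatter, so no step beyond the scatter is expected in this assay. Compound 4 is therefore expected to give 6500 nM in this assay, in a range from 2800 nM to 15000 nM. The estimated step of a 1.1-fold lower number from compound 1 to compound 4 (0.04 log units; within the scatter) would thus stay within the scatter.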

Compound 4, half-maximal inhibitory concentration: 44100 nM
Compound 4: the middle estimate sits 6.8-fold (0.83 log units) below what was measured, and the stated range ends below it.
By their numbers in this assay, from the lowest: compounds 3, 2 and 1 (each within the scatter of the next); then compound 4.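

In this assay the amide aryl group is no longer without effect: phenyl in place of methyl on the aromatic carbon para to a large group gives a clear rise (a 6.2-fold higher number from compound 1 to compound 4 (0.79 log units; beyond the scatter)), and compound 4 also stands apart from the other two amides (a 7.8-fold higher number from compound 3 to compound 4 (0.89 log units; beyond the scatter); a 7.1-fold higher number from compound 2 to compound 4 (0.85 log units; beyond the scatter)). Within the data shown here, the position therefore accepts 4-methylphenyl, 4-nitrophenyl and 3,5-dimethoxyphenyl with no difference that can be told, whereas 4-phenylphenyl is the first group here to move the number beyond the scatter, towards weaker inhibition. Nothing available bears on the reason for this loss.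

A single compound cannot show whether the loss belongs to phenyl alone or extends to other ring groups on that carbon. Cyclohexyl, morpholine or a carboxylic acid in the same place would test how far it reaches.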